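Methylating a Hydroxyamino Group: Expected Cytotoxicity of Compound 4

A few compounds are considered here, and "the series" means these few. Any claim that something is new, unique, unknown or untested is made for them only; others in the source may bear on it.

Compound 1 `CCn1cc(C(=O)O)c(=O)c2cc(F)c(N3CCN(CN4C(=O)/C(=N\NC(=S)NO)c5cc(C)ccc54)CC3)cc21` — 327000 nM
Compound 2 `CN(C)CN1C(=O)/C(=N\NC(=S)NO)c2cc(Cl)ccc21` — 610000 nM
Compound 3 `CCn1cc(C(=O)O)c(=O)c2cc(F)c(N3CCN(CN4C(=O)/C(=N\NC(=S)NOC)c5cc(C)ccc54)CC3)cc21` — 238000 nM

All three were tested in an ADME assay on MT4 cells (Homo sapiens) for cytotoxicity, read by spectrophotometry, with a stated time of 5 days; on this read-out higher numbers stand for lower toxicity in this test and lower numbers for higher toxicity in this test. Compound 3 differs from compound 1 by methyl in place of hydrogen on an oxygen, and that change gave a 1.4-fold lower number from compound 1 to compound 3 (0.14 log units; within the scatter). Compound 2 is built on another core; the difference between the two cores is not broken down here. The values of compound 2 and compound 1 lie within the scatter of each other, while the gap from compound 2 to compound 3 lies beyond it.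

The unmeasured compound 4 `CONC(=S)N/N=C1\C(=O)N(CN(C)C)c2ccc(Cl)cc21` stands to compound 2 as compound 3 stands to compound 1: the change is methyl in place of hydrogen on an oxygen, the same change at the same kind of place. For the measured compounds named here, since the one measured example of this change stayed within the scatter, only a small shift is expected on the core of compound 2 as well. The step expected here is a 1.4-fold lower number from compound 2 to compound 4 (0.14 log units; within the scatter), estimated from the earlier step of a 1.4-fold lower number from compound 1 to compound 3 (0.14 log units; within the scatter), which stayed within the scatter. Compound 4 is therefore expected to give about 440000 nM in this assay, most plausibly between 250000 nM and 800000 nM.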

Compound 4, half-maximal cytotoxic concentration: 552000 nM
Estimate against measurement, compound 4: 1.3-fold (0.10 log units) below, and the stated range covers the measured number.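

On the core of compound 2, swapping the hydroxyamino group for a methoxyamino group gave a 1.1-fold lower number from compound 2 to compound 4 (0.04 log units; within the scatter) in this assay. So this small change on the oxygen left the reading about the same on both cores, and the two steps agree with each other: the same change on two cores in this assay, a 1.4-fold lower number (0.14 log units; within the scatter) from compound 1 to compound 3 and a 1.1-fold lower number (0.04 log units; within the scatter) from compound 2 to compound 4, 1.2-fold (0.09 log units) apart, within the scatter of two such steps

This is still only two pairs of compounds in a single cell test, so it does not show that the step would stay this small on a core not shown here, or that the same would hold in any other kind of test. It also does not explain why the readings stay so close.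

The compounds shown leave open whether a longer chain on the same oxygen, such as ethyl or propyl, would also leave the reading in place. They also leave open what an amine or a carboxylic acid at that end of the molecule would do to it.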